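The compounds below may be only part of what the source reports. "The series", "measured", "known", "first", "only" and "open" are said of these compounds alone.

Measured in an assay on cells for inhibition of high affinity 3',5'-cyclic-AMP phosphodiesterase 7A (Homo sapiens), read by scintillation counting and cAMP accumulation, with a stated time of 30 min; on this read-out higher numbers stand for weaker inhibition and lower numbers for stronger inhibition:
compound 1 `CCn1c(NC2CC2)nc2ccsc2c1=O`: 2600 nM
compound 2 `CCn1c(NC(C)(C)C)nc2ccsc2c1=O`: 1500 nM
compound 3 `CCn1c(CC(C)C)nc2ccsc2c1=O`: 4700 nM

Compound 3 stands highest of the three numbers: a 1.8-fold higher number from compound 1 to compound 3 (0.26 log units; within the scatter), and a 3.1-fold higher number from compound 2 to compound 3 (0.50 log units; beyond the scatter). Compound 4 `CCNc1nc2ccsc2c(=O)n1CC` differs from compound 3 in one place: ethylamino in place of isobutyl on an aromatic carbon. Both measured steps onto compound 3 swapped an alkylamino group for isobutyl and raised the number, one within the scatter and one modestly beyond it; the change to compound 4 runs the other way, back to an alkylamino group, so a lower number of similar size is expected. Between the two alkylamino compounds themselves, a 1.7-fold lower number from compound 1 to compound 2 (0.24 log units; within the scatter), so they are not separated beyond the scatter. Compound 4 is therefore expected to show a 1.9-fold lower number from compound 3 to compound 4 (0.27 log units; within the scatter). The estimate for compound 4 is 2500 nM, with a range from 1000 nM to 6000 nM.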

Compound 4, half-maximal inhibitory concentration: 2900 nM
Compound 4: the middle estimate sits 1.2-fold (0.06 log units) below what was measured; measured number inside the range.
By their numbers in this assay, from the lowest: compounds 2, 1, 4 and 3 (each within the scatter of the next, the first and the last beyond it).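

In this assay, ethylamino in place of isobutyl on the aromatic carbon between two ring nitrogen atoms gives a 1.6-fold lower number from compound 3 to compound 4 (0.21 log units; within the scatter) and so does not separate the two groups beyond the scatter. On the amino nitrogen, ethyl is not told apart from tert-butyl or cyclopropyl, with a 1.9-fold higher number from compound 2 to compound 4 (0.29 log units; within the scatter) and a 1.1-fold higher number from compound 1 to compound 4 (0.05 log units; within the scatter) as the two steps. Nothing available explains these numbers.

Open, going by these compounds, is whether a longer chain or a carboxylic acid on that nitrogen would move the number beyond the scatter.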